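A few compounds are considered here, and "the series" means these few. Any claim that something is new, unique, unknown or untested is made for them only; others in the source may bear on it.

Compounds measured in a functional assay on A-431 cells (Homo sapiens) for inhibition, read by MTT assay, with a stated time of 72 h; on this read-out lower numbers stand for stronger inhibition and higher numbers for weaker inhibition:
- compound 1 `C/C=C/C(=O)Nc1cccc(Oc2nc(Nc3cccc(OC)c3)nc3ccsc23)c1`: 13100 nM
- compound 2 `CC/C=C/C(=O)Nc1cccc(Oc2nc(Nc3cccc(OC)c3)nc3ccsc23)c1`: 29200 nM

In this assay compound 1 gives 13100 nM, the lower of the two numbers shown, and compound 2 gives 29200 nM. Among the measured compounds shown here, the one step on record, a 2.2-fold higher number from compound 1 to compound 2 (0.35 log units; beyond the scatter), comes from methyl in place of hydrogen on a saturated chain carbon bound to a double-bonded chain carbon. Compound 3 `CCC/C=C/C(=O)Nc1cccc(Oc2nc(Nc3cccc(OC)c3)nc3ccsc23)c1` continues on the same carbon: the change from compound 1 is ethyl in place of hydrogen on a saturated chain carbon bound to a double-bonded chain carbon, that is, methyl to propyl, or prop-1-en-1-yl to pent-1-en-1-yl. For the measured compounds named here, since the single carbon added in compound 2 already raised the number beyond the scatter, a two-carbon chain in the same place is expected to move it in the same direction, by a step at least as large, estimated as a 3.1-fold higher number from compound 1 to compound 3 (0.48 log units; beyond the scatter). Compound 3 is therefore expected to give about 40000 nM, within a range of 15000 nM to 110000 nM.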

Compound 3, half-maximal inhibitory concentration: 8090 nM
The estimate for compound 3 lay 4.9-fold (0.69 log units) above the measured number, and the stated range ends above it.
By their numbers in this assay, from the lowest: compounds 3 and 1 (each within the scatter of the next); then compound 2.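

In this assay, the number at this position does not follow chain length in one direction: the ethyl of compound 3 in place of hydrogen on the saturated chain carbon bound to a double-bonded chain carbon gives a 1.6-fold lower number from compound 1 to compound 3 (0.21 log units; within the scatter) and so leaves no measurable separation from compound 1. The rise seen with the added methyl of compound 2 does not carry on, since the further methyl gives a 3.6-fold lower number from compound 2 to compound 3 (0.56 log units; beyond the scatter) and thus sets compound 2 apart from both other compounds. The data on hand offer no explanation for this turn.

As far as these compounds go, it remains open whether a longer chain such as hexyl, or a branched one such as isopropyl, would stay level with compound 1 or shift the number beyond the scatter. An amine such as dimethylamino on this same carbon also remains untested among the compounds shown.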